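A few compounds are considered here, and "the series" means these few. Any claim that something is new, unique, unknown or untested is made for them only; others in the source may bear on it.

Measured in an ADME assay on U2OS cells (Homo sapiens) for cytotoxicity; on this read-out higher numbers stand for lower toxicity in this test and lower numbers for higher toxicity in this test:
Compound 1 `CCCCCCCCc1ccc(C(=O)N/N=C/c2ccc([N+](=O)[O-])o2)cc1`: > 200000 nM (a limit, not a number)
Compound 2 `O=C(N/N=C/c1ccc([N+](=O)[O-])o1)c1ccc2ccccc2c1`: 64200 nM
Compound 3 `CCCCCC(=O)N/N=C/c1ccc([N+](=O)[O-])o1`: 19300 nM

Compound 1 stands at the limit of > 200000 nM in this assay, at which 1 of the 3 values shown sits, so it has a limit rather than a number. Compound 4 `O=C(N/N=C/c1ccc([N+](=O)[O-])o1)c1ccc(-c2ccccc2)cc1` carries phenyl in place of octyl on an aromatic carbon, para to a large group (phenyl in place of octyl on an aromatic carbon). Compound 2, which also lacks the octyl, gives 64200 nM and is the closest measured comparison. A fall in this assay beyond the scatter, toward higher toxicity, is therefore expected, with an estimated step of an at least 2.8-fold lower number from compound 1 to compound 4 (0.45 log units; beyond the scatter). For compound 4 the expected value is 70000 nM, with an estimated range of 25000 nM to 200000 nM.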

Compound 4, half-maximal cytotoxic concentration: 109000 nM
Compound 4: the middle estimate sits 1.6-fold (0.19 log units) below what was measured, and the stated range covers the measured number.
By their numbers in this assay, from the lowest: compound 3; then compounds 2 and 4 (each within the scatter of the next). At a limit, above all of these: compound 1.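

In this assay, phenyl in place of octyl on an aromatic carbon, para to a large group, gives an at least 1.8-fold lower number from compound 1 to compound 4 (0.26 log units; that floor lies within the scatter). This shows that, with phenyl at this place, the read-out becomes a number, yet no fall beyond the scatter is established for this change. Compound 1 stands at a limit, not a number, so the change can be sized only as a floor: the limit of > 200000 nM in this assay, at which 1 of the 4 values shown sits.

The compounds shown leave open how far the read-out really moves from octyl to phenyl. They also leave open how a shorter chain, an amine or a carboxylic acid on this aromatic carbon would read.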